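The compounds below may be only part of what the source reports. "The series", "measured", "known", "first", "only" and "open" are said of these compounds alone.

Compound 1 `Cc1cn([C@@H]2O[C@H](CO[Si](C)(C)C(C)(C)C)[C@@]3(OS(=O)(=O)C=C3NCC(=O)O)[C@H]2O[Si](C)(C)C(C)(C)C)c(=O)n(C)c1=O` stands at the highest of the three numbers in a functional assay on MT4 cells (Homo sapiens) (on this read-out higher numbers stand for lower toxicity in this test and lower numbers for higher toxicity in this test), giving 30000 nM. Compound 2 `Cc1cn([C@@H]2O[C@H](CO[Si](C)(C)C(C)(C)C)[C@@]3(OS(=O)(=O)C=C3NC(=O)c3ccccc3)[C@H]2O[Si](C)(C)C(C)(C)C)c(=O)n(C)c1=O` gives 4900 nM, and compound 3 `Cc1cn([C@@H]2O[C@H](CO[Si](C)(C)C(C)(C)C)[C@@]3(OS(=O)(=O)C=C3NCCC(=O)O)[C@H]2O[Si](C)(C)C(C)(C)C)c(=O)n(C)c1=O` gives 11500 nM. The largest measured step was a 6.1-fold lower number from compound 1 to compound 2 (0.79 log units; beyond the scatter); the others, a 2.6-fold lower number from compound 1 to compound 3 (0.42 log units; beyond the scatter) and a 2.3-fold higher number from compound 2 to compound 3 (0.37 log units; beyond the scatter), were smaller. Compound 4 `Cc1cn([C@@H]2O[C@H](CO[Si](C)(C)C(C)(C)C)[C@@]3(OS(=O)(=O)C=C3NC(=O)NC(=O)c3ccccc3)[C@H]2O[Si](C)(C)C(C)(C)C)c(=O)n(C)c1=O` has not been measured and differs from compound 1 by benzoylcarbamoyl in place of carboxymethyl on an amine nitrogen. Among the measured compounds shown here, only one measured step bears on this change: a lower number of similar size is expected for compound 4 because a 6.1-fold lower number from compound 1 to compound 2 (0.79 log units; beyond the scatter) likewise replaced the carboxymethyl with a group carrying a benzoyl. Compound 4 is therefore estimated at 5500 nM, with a range of 2000 nM to 15000 nM, which would amount to a 5.5-fold lower number from compound 1 to compound 4 (0.74 log units; beyond the scatter).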

Compound 4, half-maximal cytotoxic concentration: 3330 nM
The estimate for compound 4 lay 1.7-fold (0.22 log units) above the measured number, and the stated range covers the measured number.
By their numbers in this assay, from the lowest: compounds 4 and 2 (each within the scatter of the next); then compound 3; then compound 1.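

In this assay, benzoylcarbamoyl in place of carboxymethyl on the amine nitrogen gave a 9.0-fold lower number from compound 1 to compound 4 (0.95 log units; beyond the scatter), and in place of 2-carboxyethyl it gave a 3.5-fold lower number from compound 3 to compound 4 (0.54 log units; beyond the scatter). Benzamido in place of phenyl on the carbonyl carbon gave a 1.5-fold lower number from compound 2 to compound 4 (0.17 log units; within the scatter), so this read-out does not separate the two benzoyl-bearing groups. No measurement at hand accounts for these differences. From the compounds shown here alone, it remains open whether an acetyl group on this nitrogen would fall with compound 2 and compound 4 or nearer compound 1, and whether a fluorine or methoxy group on the phenyl ring would shift the number.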